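The source may hold more compounds than are shown below. What is called first, only, known or untested is meant among the compounds shown, and "the series" means these compounds.

The series shares the core shown for compound 1 `Cc1cc(-c2ccco2)cn2c(CSCCc3ccccc3)cnc12`, compound 2 `Cc1cc(-c2ccoc2)cn2c(CSCCc3ccccc3)cnc12` and compound 3 `Cc1cc(N2CCCC2=O)cn2c(CSCCc3ccccc3)cnc12`. Among the measured compounds shown here, in an ADME assay on HEL cells (Homo sapiens) for cytotoxicity, with a stated time of 3 days (a higher number here means that more compound is tolerated, a lower number that less compound is tolerated), every value so far is a limit of the assay, not a number. In this assay compound 1 gives a limit of > 4 ug/mL. Compound 2 likewise gives a limit of > 4 ug/mL. Compound 3 gives a limit of > 100 ug/mL, which is the limit of > 100 ug/mL in this assay, at which 1 of the 3 values shown sits, while the other two values sit at the limit of > 4 ug/mL in this assay, at which 2 of the 3 values shown sit. The steps a step that the two limits leave unreadable from compound 1 to compound 2, a step that the two limits leave unreadable from compound 1 to compound 3 and a step that the two limits leave unreadable from compound 2 to compound 3 are therefore unreadable, so compound 3 stands on a different limit from the other two and nothing more can be said of its place.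

Compound 4 `Cc1cc(-n2cccc2)cn2c(CSCCc3ccccc3)cnc12` differs from compound 3 as follows: 1H-pyrrol-1-yl in place of 2-oxopyrrolidin-1-yl on an aromatic carbon. For the measured compounds named here, no measured step gives a readable size to carry over. Compound 1 and compound 2, which both carry a five-membered aromatic ring on the same aromatic carbon, sit at the limit of > 4 ug/mL in this assay, at which 2 of the 3 values shown sit. Compound 4 is expected to return 20 ug/mL in this assay, within 4 ug/mL to 100 ug/mL, most likely again as a limit. The step of an at least 5.0-fold lower number from compound 3 to compound 4 (0.69 log units; beyond the scatter) is expected only as a rough size, since compound 3 itself is a limit.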

Compound 4, minimum cytotoxic concentration: >= 4 ug/mL
Compound 4 was reported as a limit (the forecaster's own chance of this, stated with the estimate: 70%); the middle value is on the limit's open side.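

In this assay compound 4 gives >= 4 ug/mL, which is a limit of the assay. Among the compounds shown here, no step between compound 4 and compound 1, compound 2 or compound 3 can be read. The compounds shown leave open how far the tolerated concentrations of these four compounds actually differ.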